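The compounds below may be only part of what the source reports. "The series", "measured", "known", "first", "only" and "open" are said of these compounds alone.

Measured so far:
compound 1, `O=C([N-][n+]1ccccc1C1=CC(CF)(CF)Oc2ccc([N+](=O)[O-])cc21)c1ccccc1`, in a functional assay (aorta) with Rattus norvegicus as the target (a lower number here means that less compound is needed, a higher number that more compound is needed for the effect), gives < 10000 nM, a limit of the assay rather than a number.
compound 2, `CS(=O)(=O)[N-][n+]1ccccc1C1=CC(CF)(CF)Oc2ccc([N+](=O)[O-])cc21`, in this assay gives 3020 nM.

Among the compounds with values here, compound 2 is the only compound with a readable number in this assay; the other value shown is a limit. The step that the limit leaves unreadable from compound 1 to compound 2 therefore cannot be read, because the value of compound 1 sits at the limit of < 10000 nM in this assay, at which 1 of the 2 values shown sits. What is known of the benzoyl compound is only that it also produced an effect within the tested range.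

Compound 3, `O=C([N-][n+]1ccccc1C1=CC(CF)(CF)Oc2ccc([N+](=O)[O-])cc21)Nc1ccccc1`, is not yet measured. It differs from compound 2 by phenylcarbamoyl in place of methylsulfonyl on a nitrogen on an aromatic ring. Within the data shown here, the only measured step touches the same nitrogen, exchanging benzoyl for methylsulfonyl, but its size is hidden by the limit, so it gives no guide to the size or direction of the present change. Both measured compounds reach a readable effect or a limit in the same region, so no step beyond the scatter is expected here. Compound 3 is therefore estimated at 3000 nM, with a range from 900 nM to 10000 nM, which means an expected step of a 1.0-fold lower number from compound 2 to compound 3 (0.00 log units; within the scatter).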

Compound 3, half-maximal effective concentration: 9120 nM
Estimate against measurement, compound 3: 3.0-fold (0.48 log units) below; the range from low to high includes it.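

In this assay, the group on this nitrogen gives a first readable change: phenylcarbamoyl in place of methylsulfonyl produces a 3.0-fold higher number from compound 2 to compound 3 (0.48 log units; beyond the scatter), so more compound is needed for the same effect. The position is therefore not indifferent to what it carries, although the exchange alters several things at once, bringing in a six-membered aromatic ring and a hydrogen-bond donor and replacing the sulfonyl link with a carbonyl, so the shift cannot be assigned to any one of them. Compound 1 is held only by a limit of the assay, and its steps to compound 2 and compound 3 therefore cannot be read, which leaves the comparison of benzoyl with anilino on the carbonyl carbon without a size: the limit of < 10000 nM in this assay, at which 1 of the 3 values shown sits.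

From the compounds shown here alone, what remains open is which part of the phenylcarbamoyl group goes with the higher number, the aromatic ring, the amide hydrogen or the carbonyl link. A methylcarbamoyl or acetyl group on the same nitrogen would help to separate these parts, while an ethylsulfonyl group would show how this position responds to a longer chain on the sulfonyl.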